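Diyne nucleoside series: shortening the hydroxyalkyl arm

The source may hold more compounds than are shown below. What is called first, only, known or untested is meant among the compounds shown, and "the series" means these compounds.

Compound 1 `O=c1[nH]c(=O)n([C@H]2C[C@H](O)[C@@H](CO)O2)cc1C#CC#Cc1ccc([N+](=O)[O-])cc1` and compound 2 `CC(O)CC#CC#Cc1cn([C@H]2C[C@H](O)[C@@H](CO)O2)c(=O)[nH]c1=O` share one core and differ only at the far end of the diyne chain. In an ADME assay on HEL cells (Homo sapiens) for cytotoxicity, read by microscopy (a lower number here means that less compound is tolerated, a higher number that more compound is tolerated), compound 1 gives 100000 nM. In this assay compound 2 gives > 100000 nM, which is a limit of the assay and not a number. The step of a number no lower from compound 1 to compound 2 (the limit leaves the size open) therefore cannot be sized; it shows only that tolerance did not fall. Compound 2 thus stands at the ceiling of the measured range, as the limit of > 100000 nM in this assay, at which 1 of the 2 values shown sits, records. Compound 3 `O=c1[nH]c(=O)n([C@H]2C[C@H](O)[C@@H](CO)O2)cc1C#CC#CCO` is not yet measured; against compound 2 the change is hydroxy in place of 1-hydroxyethyl on a saturated chain carbon bound to a triple-bonded carbon. Among the measured compounds shown here, the single measured step bears on it only in that both measured compounds sit at or beyond the top of the tested range, so no step beyond the scatter is expected in this assay a number no higher from compound 2 to compound 3 (the limit leaves the size open). Compound 3 is expected to give 100000 nM, between 50000 nM and 200000 nM, most likely reported again as a limit.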

Compound 3, minimum cytotoxic concentration: > 100000 nM
Compound 3: only a limit was reported; the forecaster's own chance of this, stated with the estimate: 70%; the middle value sits exactly at the limit.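

In this assay compound 3 gives > 100000 nM, a limit of the assay and not a number, so with hydroxy in place of 1-hydroxyethyl the reading stays at the limit. Hydroxymethyl in place of 4-nitrophenyl gives a number no lower from compound 1 to compound 3 (the limit leaves the size open), and no step among these compounds can be sized, including the one between the two hydroxyalkyl arms. Both hydroxyalkyl arms, 2-hydroxypropyl and hydroxymethyl, now read as limits, whereas compound 1 carries a number: the limit of > 100000 nM in this assay, at which 2 of the 3 values shown sit.

On these data alone, how far the true values of compound 2 and compound 3 lie past the limit stays open, and with it any order between them. Also open, as far as these compounds go, is how a longer chain, an amine or a carboxylic acid at the far end of the diyne chain would read in this assay.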